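Selenocyanate chain length on an ether-linked quinazoline core

The source may report more compounds than this note shows. Statements on the series, on what has been measured and on what is new or still open speak of the compounds shown alone.

The series has three measured members. Compound 1 `COc1ccc(N(C)c2nc(C)nc3ccccc23)cc1C(=O)OCC[Se]C#N` carries a short selenocyanate-bearing chain on an ester, and in a functional assay on LoVo cells (Homo sapiens) for inhibition, read by MTT assay, with a stated time of 48 h (a higher number here means a weaker inhibitor, a lower number a stronger inhibitor), compound 1 gives 2960 nM. Compound 2 `COc1ccc(N(C)c2nc(C)nc3ccccc23)cc1C(=O)OCCCC[Se]C#N` keeps the same core and differs by a group of 5 heavy atoms (3 carbon, 1 nitrogen, 1 selenium; no ring) in place of a group of 3 heavy atoms (1 carbon, 1 nitrogen, 1 selenium; no ring), on a saturated chain carbon, two bonds along the chain from an oxygen next to a carbonyl group; in this assay compound 2 gives 1080 nM. That change made a step of a 2.7-fold lower number from compound 1 to compound 2 (0.44 log units; beyond the scatter). Compound 3 `COc1ccc(N(C)c2nc(C)nc3ccccc23)cc1OCC[Se]C#N` differs from compound 1 by a group of 6 heavy atoms (3 carbon, 1 nitrogen, 1 oxygen, 1 selenium; no ring) in place of a group of 8 heavy atoms (4 carbon, 1 nitrogen, 2 oxygen, 1 selenium; no ring), on an aromatic carbon, so the ester linker gives way to an ether linker, and in this assay compound 3 gives 19 nM. The steps to compound 3 are the large ones of the set: a 160-fold lower number from compound 1 to compound 3 (2.19 log units; beyond the scatter) and a 57-fold lower number from compound 2 to compound 3 (1.75 log units; beyond the scatter). Compound 3 therefore stands at the lowest number of the three, and both of its steps lie beyond the scatter.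

Compound 4 `COc1ccc(N(C)c2nc(C)nc3ccccc23)cc1OCCCC[Se]C#N` has not been measured. It differs from compound 3 by a group of 5 heavy atoms (3 carbon, 1 nitrogen, 1 selenium; no ring) in place of a group of 3 heavy atoms (1 carbon, 1 nitrogen, 1 selenium; no ring), on a saturated chain carbon, two bonds along the chain from an oxygen on an aromatic ring. This is the same kind of change that took compound 1 to compound 2, but not the same: there the longer chain sat on a saturated chain carbon two bonds along the chain from an oxygen next to a carbonyl group, here it sits on a saturated chain carbon two bonds along the chain from an oxygen on an aromatic ring. Because the earlier step was a 2.7-fold lower number from compound 1 to compound 2 (0.44 log units; beyond the scatter), a step of about a 2.4-fold lower number from compound 3 to compound 4 (0.38 log units; beyond the scatter) is expected from compound 3 to compound 4, with added width since the surroundings differ. Compound 4 is thus estimated to give 8 nM in this assay, within a range from 3 nM to 25 nM.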

Compound 4, half-maximal inhibitory concentration: 882 nM
For compound 4 the middle estimate is 110-fold (2.04 log units) below the measured one; the whole stated range lies below it.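

In this assay the chain lengthening did not carry over from the ester to the ether: the step on the ether was a 46-fold higher number from compound 3 to compound 4 (1.67 log units; beyond the scatter), and set beside the earlier step on the ester, the same change ran in opposite directions on the two cores: the same change on two cores in this assay, a 2.7-fold lower number (0.44 log units; beyond the scatter) from compound 1 to compound 2 and a 46-fold higher number (1.67 log units; beyond the scatter) from compound 3 to compound 4, 130-fold (2.10 log units) apart, beyond the scatter of two such steps With the longer chain in place, the linker swap left the two compounds within the scatter of each other, at a 1.2-fold lower number from compound 2 to compound 4 (0.09 log units; within the scatter), so the large gain seen for the ether belongs to compound 3 alone among the ether compounds, while the listed step that changes both chain and linker together is only a 3.4-fold lower number from compound 1 to compound 4 (0.53 log units; beyond the scatter). This shows that a step measured on one core could not be transferred to the other here, but it rests on a single pair of steps in one cell line and does not show why the two cores part ways.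

The compounds shown leave open whether the low number of compound 3 would survive on a chain of intermediate length or a longer chain than either shown. They also leave open how an amide in place of the ester or ether, or a thiocyanate in place of the selenocyanate, would behave at either chain length.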